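The compounds below may be only part of what the source reports. "The series", "measured", "known", "first", "only" and "open" are said of these compounds alone.

Measured so far, in an assay on HEK293 cells for displacement of a labelled ligand from 5-hydroxytryptamine receptor 6 (Homo sapiens), with a stated time of 60 min, tested at 1 uM, in the presence of a further agent that is not named here; a higher number here means a stronger effect of the compound at the concentration tested, a lower number a weaker effect:
- compound 1 `COc1cc(N)c(Cl)cc1C(=O)CCC1CCN(CCNS(=O)(=O)c2ccc(NC(C)=O)cc2)CC1` gives 67%
- compound 2 `COc1cc(N)c(Cl)cc1C(=O)CCC1CCN(CCNS(=O)(=O)c2cc(Br)c(N)c(Br)c2)CC1` gives 83%
- compound 3 `COc1cc(N)c(Cl)cc1C(=O)CCC1CCN(CCNS(=O)(=O)c2cc(Br)ccc2Br)CC1` gives 52%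

Compound 3 stands lowest of the three in this assay: a number 15 percentage points lower from compound 1 to compound 3 (beyond the scatter) and a number 31 percentage points lower from compound 2 to compound 3 (beyond the scatter), both beyond the scatter.

Compound 4 `COc1ccc(S(=O)(=O)NCCN2CCC(CCC(=O)c3cc(Cl)c(N)cc3OC)CC2)cc1` differs from compound 3 as follows: 4-methoxyphenyl in place of 2,5-dibromophenyl on a sulfonyl sulfur. For the measured compounds named here, no measured step involves 4-methoxyphenyl. The nearest guide is the step from compound 1, which bears 4-acetamidophenyl on the sulfonyl sulfur, to compound 3, namely a number 15 percentage points lower from compound 1 to compound 3 (beyond the scatter); reading it in reverse suggests that leaving 2,5-dibromophenyl gains a modest amount. As far as these compounds go, a modest rise is therefore expected, a number 10 percentage points higher from compound 3 to compound 4 (within the scatter), with wide uncertainty since the methoxy variant is untested. Compound 4 is estimated at 62%, range 45% to 78%.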

Compound 4, a percentage reported as inhibition, at one concentration (the size of the read-out at that concentration, not a potency): 52%
Compound 4: the middle estimate sits 10 percentage points above what was measured, and the stated range covers the measured number.
By their numbers in this assay, from the lowest: compounds 3 and 4 (each within the scatter of the next); then compound 1; then compound 2.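

In this assay, 4-methoxyphenyl in place of 2,5-dibromophenyl on a sulfonyl sulfur gives (no change at the digits printed from compound 3 to compound 4 (within the scatter)), so two differently substituted aryl groups read alike at this position. Compound 4 stays well short of the 4-amino-3,5-dibromophenyl analogue (a number 31 percentage points lower from compound 2 to compound 4 (beyond the scatter)) and also short of the 4-acetamidophenyl analogue (a number 15 percentage points lower from compound 1 to compound 4 (beyond the scatter)), so these two groups remain the better ones here. Nothing measured explains these steps.

Open, as far as these compounds go, is whether 4-aminophenyl, without bromine, would hold the read-out of compound 2. From the compounds shown here alone, a carboxylic acid on this ring also remains open.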